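The compounds below may be only part of what the source reports. "The series", "measured", "known", "first", "only" and "open" are said of these compounds alone.

Measured compounds:
- compound 1, `Cc1ccc(-c2csc(NC(=O)COc3ccccc3C)n2)cc1`: 54400 nM in a functional assay on Ehrlich cells (Mus musculus) for cytotoxicity, read by MTT assay, with a stated time of 48 h; on this read-out lower numbers stand for stronger inhibition and higher numbers for weaker inhibition
- compound 2, `Cc1ccc(-c2csc(NC(=O)COc3ccc(F)cc3F)n2)cc1`: in this assay compound 2 gives 14900 nM
- compound 3, `Cc1ccccc1OCC(=O)Nc1nc(-c2ccc(Br)cc2)cs1`: in this assay compound 3 gives 44900 nM

Compound 4, `O=C(COc1ccc(F)cc1F)Nc1nc(-c2ccc(Br)cc2)cs1`, is not yet measured in this assay.

For the measured compounds named here, the measured step that matters for compound 4 is the one from compound 1 to compound 2: 2,4-difluorophenyl in place of 2-methylphenyl on an oxygen on a saturated carbon. That change gave a 3.7-fold lower number from compound 1 to compound 2 (0.56 log units; beyond the scatter). Compound 3 differs from compound 1 only in its core: bromo in place of methyl on an aromatic carbon. On that pair the difference gave a 1.2-fold lower number from compound 1 to compound 3 (0.08 log units; within the scatter), so compound 1 and compound 3 sit within the scatter of each other in this assay.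

Compound 4 stands to compound 3 as compound 2 stands to compound 1: 2,4-difluorophenyl in place of 2-methylphenyl on an oxygen on a saturated carbon. The place of the change is described in the same words for both pairs, so this is the same change carried onto the core of compound 3. Going by the values given here, the one precedent is the step from compound 1 to compound 2, and the two cores are close in this assay, so the step from compound 3 to compound 4 is expected to be of similar size, estimated as a 3.5-fold lower number from compound 3 to compound 4 (0.54 log units; beyond the scatter). On that basis compound 4 is expected to give about 13000 nM in this assay, with a range from 6000 nM to 35000 nM, the width reflecting that a single precedent cannot settle how far the step carries over to a second core.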

Compound 4, half-maximal inhibitory concentration: 44200 nM
Beside the measured number, compound 4's estimate is 3.4-fold (0.53 log units) below it; the measured number lies above the stated range.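

On the core of compound 3, 2,4-difluorophenyl in place of 2-methylphenyl gives a 1.0-fold lower number from compound 3 to compound 4 (0.01 log units; within the scatter), so the step seen on the core of compound 1 does not carry over in this assay: the same change on two cores in this assay, a 3.7-fold lower number (0.56 log units; beyond the scatter) from compound 1 to compound 2 and a 1.0-fold lower number (0.01 log units; within the scatter) from compound 3 to compound 4, 3.6-fold (0.56 log units) apart, beyond the scatter of two such steps. Read the other way, bromo in place of methyl on an aromatic carbon gives a 3.0-fold higher number from compound 2 to compound 4 (0.47 log units; beyond the scatter) when 2,4-difluorophenyl is present, so the two changes do not add up independently in this assay: the same change on two cores in this assay, a 1.2-fold lower number (0.08 log units; within the scatter) from compound 1 to compound 3 and a 3.0-fold higher number (0.47 log units; beyond the scatter) from compound 2 to compound 4, 3.6-fold (0.56 log units) apart, beyond the scatter of two such steps. This shows that, within these four compounds, the lower number comes only with 2,4-difluorophenyl and the methyl-bearing core together, and that a step measured on one core is no safe guide to the other; it does not show why the two changes interact, or whether the same holds for any other pair of groups.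

Still open, on these data alone, is whether this dependence on the core extends to other groups on the oxygen, such as an unsubstituted phenyl, a 4-chlorophenyl or a longer alkyl chain. Also open, as far as these compounds go, is how a chloro or methoxy group in place of the bromo would behave with each of the two groups on the oxygen, which would show whether the interaction is particular to bromo.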